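The compounds below may be only part of what the source reports. "The series", "measured", "known", "first", "only" and "open" are said of these compounds alone.

Measured so far:
compound 1 `COC(=O)c1nc(C)n(-c2ccc(F)cc2)n1` with 11700 nM
compound 2 `COC(=O)c1nc(C(C)C)n(-c2ccc(F)cc2)n1` with 6170 nM

Both were tested in a functional assay on NCI-H226 cells (Homo sapiens) for inhibition, read by MTT assay, with a stated time of 72 h; on this read-out lower numbers stand for stronger inhibition of growth and higher numbers for weaker inhibition of growth. Compound 2 gives the lower of the two numbers, but its gap to compound 1 lies within the scatter, so neither can be ranked above the other. Going by the values given here, the only measured step, a 1.9-fold lower number from compound 1 to compound 2 (0.28 log units; within the scatter), bears on the next change, in which compound 3 `CCCCc1nc(C(=O)OC)nn1-c1ccc(F)cc1` arises from compound 2 by butyl in place of isopropyl on an aromatic carbon. Since that earlier enlargement of the alkyl group on the same aromatic carbon produced no step beyond the scatter, a similar outcome is expected here, namely a 1.2-fold lower number from compound 2 to compound 3 (0.09 log units; within the scatter). Compound 3 is therefore estimated at 5000 nM, with a range from 2000 nM to 15000 nM.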

Compound 3, concentration for 50% growth inhibition: 6400 nM
For compound 3 the middle estimate is 1.3-fold (0.11 log units) below the measured one, within the range that was stated.
By their numbers in this assay, from the lowest: compounds 2, 3 and 1 (each within the scatter of the next).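

In (this assay), butyl on this aromatic carbon, between two ring nitrogen atoms, stays within the scatter of isopropyl (a 1.0-fold higher number from compound 2 to compound 3 (0.02 log units; within the scatter)) and also of methyl (a 1.8-fold lower number from compound 1 to compound 3 (0.26 log units; within the scatter)). Across compound 1, compound 2 and compound 3, a branched and an unbranched chain at this position therefore give no step beyond the scatter. No independent evidence bears on this result. The compounds shown leave open whether an amine or a carboxylic acid on this carbon would move the number. From the compounds shown here alone, whether a longer chain, such as octyl, would do so also remains open.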